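The compounds below may be only part of what the source reports. "The series", "measured", "known", "first", "only" and "open" are said of these compounds alone.

Measured compounds in an assay on liver for inhibition of sterol O-acyltransferase 1 (Rattus norvegicus), using microsomes; a lower number here means a stronger inhibitor, a higher number a weaker inhibitor:
compound 1 `CCOC(=O)NS(=O)(=O)Oc1c(C(C)C)cccc1C(C)C`; compound 2 `CC(C)c1cccc(C(C)C)c1OS(=O)(=O)NC(=O)OC1CCCCC1`; compound 3 `CC(C)c1cccc(C(C)C)c1OS(=O)(=O)NC(=O)Oc1c(F)cccc1F`

Compound 1 gives only a limit in this assay, > 50000 nM; > 50000 nM (2 entries), twice. Compound 2 gives 38000 nM. Compound 3 gives 65000 nM, the highest of the two numbers recorded, though its nearest neighbour is compound 2 and the step of a 1.7-fold higher number from compound 2 to compound 3 (0.23 log units; within the scatter) is within the scatter, so no order can be claimed between them.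

Compound 4 `Cc1cccc(C)c1OC(=O)NS(=O)(=O)Oc1c(C(C)C)cccc1C(C)C` differs from compound 3 in one place: 2,6-dimethylphenyl in place of 2,6-difluorophenyl on an oxygen next to a carbonyl group. Going by the values given here, the only measured step bearing on this position is the exchange of the group on the oxygen next to the carbonyl, a 1.7-fold higher number from compound 2 to compound 3 (0.23 log units; within the scatter), which did not move the number beyond the scatter. With one step of this kind and no movement in it, no change beyond the scatter is expected in this assay, and the step of a 1.2-fold lower number from compound 3 to compound 4 (0.07 log units; within the scatter) is estimated accordingly. Compound 4 is therefore expected near 55000 nM, within 20000 nM to 150000 nM, with a real chance that only a limit is reported.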

Compound 4, half-maximal inhibitory concentration: > 50000 nM
Compound 4 gave a limit, no number (the forecaster's own chance of this, stated with the estimate: 40%); the middle value does not contradict the limit.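

In this assay compound 4 gives only a limit of > 50000 nM and so no number, which leaves its step from compound 3 unreadable. Going by these compounds alone, the one step that can be read is an at least 1.3-fold higher number from compound 2 to compound 4 (0.11 log units; that floor lies within the scatter) and gives no order between 2,6-dimethylphenyl and cyclohexyl on an oxygen next to a carbonyl group. With 2,6-dimethylphenyl, this position now adds a second aromatic group after 2,6-difluorophenyl without giving a step beyond the scatter, and its readings now reach the assay limit: the limit of > 50000 nM in this assay, at which 1 of the 4 values shown sits.

Open, going by these compounds, is whether a longer alkyl chain, or a group carrying an amine or a carboxylic acid, on this oxygen would give a number beyond the scatter from those of compound 2 and compound 3. On these data alone, what a change in the shared core would do also stays open.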